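A few compounds are considered here, and "the series" means these few. Any claim that something is new, unique, unknown or untested is made for them only; others in the source may bear on it.

Compound 1 `CCCCC/N=C(\NC#N)Nc1cccnc1`: in a functional assay on the whole organism (blood, strain Wistar-Okamoto) with Rattus norvegicus as the target, with a stated time of 5 days (on this read-out higher numbers stand for an effect only at larger amounts of compound and lower numbers for an effect already at smaller amounts), compound 1 gives 20 mg/kg
Compound 2 `CC(C)/N=C(\NC#N)Nc1cccnc1`: compound 2 gives 2.5 mg/kg
Compound 3 `CC(C)C(C)(C)/N=C(\NC#N)Nc1cccnc1`: compound 3 gives 1 mg/kg

Compound 3 holds the lowest number of the three, with compound 2 nearest and compound 1 furthest. The next entry is compound 4 `CC1(/N=C(\NC#N)Nc2cccnc2)CCC1`, which differs from compound 3 in one place: 1-methylcyclobutyl in place of 1,1,2-trimethylpropyl on a double-bonded nitrogen. Among the compounds with values here, the steps that bear on this change are a 20-fold lower number from compound 1 to compound 3 (1.30 log units; beyond the scatter) and a 2.5-fold lower number from compound 2 to compound 3 (0.40 log units; beyond the scatter); both run towards lower numbers as the group on the double-bonded nitrogen becomes more branched. The 1-methylcyclobutyl group keeps that branching at the carbon on the nitrogen, so only a small rise is expected, a step of a 1.5-fold higher number from compound 3 to compound 4 (0.18 log units; within the scatter) lying within the scatter. For compound 4 the expected value is 1.5 mg/kg, with a range from 0.5 mg/kg to 5 mg/kg.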

Compound 4, minimum effective dose: 50 mg/kg
For compound 4 the middle estimate is 33-fold (1.52 log units) below the measured one; the measured number lies above the stated range.
By their numbers in this assay, from the lowest: compound 3; then compound 2; then compound 1; then compound 4.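

The run towards lower numbers with branching at this place breaks with the 1-methylcyclobutyl group (a 50-fold higher number from compound 3 to compound 4 (1.70 log units; beyond the scatter); a 20-fold higher number from compound 2 to compound 4 (1.30 log units; beyond the scatter)). Even the pentyl group gives a lower number (a 2.5-fold higher number from compound 1 to compound 4 (0.40 log units; beyond the scatter)), so a fully substituted carbon on the double-bonded nitrogen is not enough for a low number in this short series. No available measurement accounts for this reversal. Still open, from the compounds shown here alone, is whether the ring as such or its size decides the outcome. Tert-butyl and 1-methylcyclopentyl on the same nitrogen would help separate these two readings.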